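This account rests on a few compounds, and the source may have more. Where it says the series, first, only, none or still open, it means among the compounds named here.

Among the measured compounds shown here, in a functional assay on the whole organism with Scenedesmus acutus as the target, with a stated time of 20 h (a higher number here means a weaker inhibitor, a lower number a stronger inhibitor), compound 2 (`CC(C)COC(=O)c1cc(N2C(=O)C3=C(CCCC3)C2=O)c(F)cc1Cl`) gives 407 nM, so far the only actual number. Compound 1 (`O=C(O)c1cc(N2C(=O)C3=C(CCCC3)C2=O)ccc1Cl`) reads > 100000 nM, which is a limit of the assay. Compound 3 (`CC(C)COC(=O)c1cc(N2C(=O)C3=C(CCCC3)C2=O)ccc1Cl`) differs from compound 2 in one place: hydrogen in place of fluoro on an aromatic carbon. For the measured compounds named here, no measured pair isolates this change, so the size of the step rests on judgement alone. A moderate weakening in this assay is expected, with a range that still allows no change beyond the scatter. The expected shift is a 2.9-fold higher number from compound 2 to compound 3 (0.47 log units; beyond the scatter). For compound 3 the estimated value is 1200 nM, with an expected range of 350 nM to 5000 nM.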

Compound 3, half-maximal inhibitory concentration: 15500 nM
For compound 3 the middle estimate is 13-fold (1.11 log units) below the measured one; measured number above the stated range.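

In this assay, hydrogen in place of fluoro on this aromatic carbon, ortho to a large group, gives a 38-fold higher number from compound 2 to compound 3 (1.58 log units; beyond the scatter), so this single atom carries much of the potency of compound 2. Isobutyl in place of hydrogen on the oxygen next to a carbonyl group gives an at least 6.4-fold lower number from compound 1 to compound 3 (0.80 log units; beyond the scatter), and without fluoro the ester stays far from compound 2. That step is only a bound, since one end of it is a limit: the limit of > 100000 nM in this assay, at which 1 of the 3 values shown sits.

Open, going by these compounds, is whether bromo, methoxy or a nitrile on this carbon would match fluoro. Also open, on these data alone, is whether a longer chain on the ester oxygen would change the size of the fluoro step.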